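The compounds below may be only part of what the source reports. "The series", "measured", "known", "first", "only" and "open" are said of these compounds alone.

In a functional assay on HCT-8 cells (Homo sapiens) for cytotoxicity (on this read-out lower numbers stand for an effect already at smaller amounts and higher numbers for an effect only at larger amounts of compound), compound 2 `COC1=C(C)C(=O)/C(=C(O)/C=C/c2ccccc2C)C(=O)C1(C)C` gives 4 ug/mL. Compound 1 `COC1=C(C)C(=O)/C(=C(O)/C=C/c2ccc(Br)cc2)C(=O)C1(C)C` gives 7.4 ug/mL, within the scatter of the number for compound 2. Compound 3 `COC1=C(C)C(=O)/C(=C(O)/C=C/c2c(C)cc(C)cc2C)C(=O)C1(C)C` gives 8.4 ug/mL, which stands higher than the number for compound 2 by slightly more than the scatter. Compound 2 therefore sits at the low end of the three numbers, level with compound 1 and just clear of compound 3.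

Compound 4 `COC1=C(C)C(=O)/C(=C(O)/C=C/c2nccs2)C(=O)C1(C)C` keeps the shared core and changes one group: 1,3-thiazol-2-yl in place of 2-methylphenyl on a double-bonded chain carbon bound to a double-bonded chain carbon. Here 1,3-thiazol-2-yl takes the place of 2-methylphenyl on a double-bonded chain carbon bound to a double-bonded chain carbon.

For the measured compounds named here, only one measured step bears directly on this change: a 1.9-fold lower number from compound 1 to compound 2 (0.27 log units; within the scatter). It concerns the same place, but it exchanges one substituted phenyl for another. Going by the values given here, no measured compound carries a five-membered aromatic ring there, so the data offer no direct precedent for the new group and the uncertainty is wide. With only a small step seen at this place, a large one is not expected in this assay. The estimated step is a 1.5-fold higher number from compound 2 to compound 4 (0.18 log units; within the scatter), so no change beyond the scatter is expected. For compound 4 the estimated value is 6 ug/mL, with an expected range from 2.5 ug/mL to 14 ug/mL.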

Compound 4, concentration for half-maximal effect: 5.1 ug/mL
Estimate against measurement, compound 4: 1.2-fold (0.07 log units) above; the measured number falls inside the stated range.
By their numbers in this assay, from the lowest: compounds 2, 4, 1 and 3 (each within the scatter of the next, the first and the last beyond it).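

In this assay the place on a double-bonded chain carbon bound to a double-bonded chain carbon accepts more than a substituted phenyl: with 1,3-thiazol-2-yl in place of 2-methylphenyl the result is a 1.3-fold higher number from compound 2 to compound 4 (0.11 log units; within the scatter) and with 1,3-thiazol-2-yl in place of 4-bromophenyl it is a 1.5-fold lower number from compound 1 to compound 4 (0.16 log units; within the scatter) and so neither exchange moves the number beyond the scatter. The earlier compounds shown here showed only phenyl rings here, whereas this change brings in one five-membered aromatic ring with 2 hetero atoms and 2 hydrogen-bond acceptors, against 0 in 2-methylphenyl, and the read-out stays level with both compounds. Nothing measured here accounts for this outcome.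

On these data alone, all the groups seen at this place are aromatic rings, so it remains open whether an amine, a carboxylic acid or a longer chain there would shift the number beyond the scatter. As far as these compounds go, it is equally open whether the level result holds for other five-membered rings, such as furan-2-yl or thiophen-2-yl, or depends on the thiazole itself.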